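A few compounds are considered here, and "the series" means these few. Any claim that something is new, unique, unknown or untested is made for them only; others in the source may bear on it.

Measured in an ADME assay on MT4 cells (Homo sapiens) for cytotoxicity, read by MTT assay, with a stated time of 96 h; a lower number here means that less compound is tolerated, a higher number that more compound is tolerated:
- Compound 1 `CCC(=O)Oc1ccc2ccc(=O)oc2c1Cc1c(-c2ccccc2)[nH]c2ccccc12`: > 100000 nM (a limit)
- Compound 2 `CC(=O)Oc1ccc2ccc(=O)oc2c1Cc1c(-c2ccccc2)[nH]c2ccccc12`: > 100000 nM (a limit)
- Compound 3 `CC(=O)Oc1ccc2ccc(=O)oc2c1Cc1c(C)[nH]c2ccccc12`: 62000 nM

Going by the values given here, compound 3 holds the only true number in this set. The other two compounds sit at the limit of > 100000 nM in this assay, at which 2 of the 3 values shown sit.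

Compound 4 `CCC(=O)Oc1ccc2ccc(=O)oc2c1Cc1c(C)[nH]c2ccccc12` differs from compound 3 by one change: methyl in place of hydrogen on a saturated chain carbon bound to a carbonyl carbon, turning acetoxy to propanoyloxy. The same change run in reverse is a step that the two limits leave unreadable from compound 1 to compound 2, so the closest comparison gives no size. The other measured step, an at least 1.6-fold lower number from compound 2 to compound 3 (0.20 log units; that floor lies within the scatter), lies at a different place, on an aromatic carbon. No step beyond the scatter is therefore expected in this assay, and the expected size is a 1.0-fold higher number from compound 3 to compound 4 (0.02 log units; within the scatter). The estimate for compound 4 is 65000 nM, with an expected range of 35000 nM to 100000 nM.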

Compound 4, half-maximal cytotoxic concentration: 80000 nM
Estimate against measurement, compound 4: 1.2-fold (0.09 log units) below; low and high end bracket the measured number.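

In this assay, the change from acetoxy to propanoyloxy now has a readable size, a 1.3-fold higher number from compound 3 to compound 4 (0.11 log units; within the scatter), so compounds carrying methyl on the aromatic carbon cannot be told apart by this change. On the phenyl compounds, the same change remains unreadable, since compound 1 and compound 2 both sit at a limit. Methyl in place of phenyl now reads on the propanoyloxy pair as well, as an at least 1.2-fold lower number from compound 1 to compound 4 (0.09 log units; that floor lies within the scatter), and the two pairs compare only loosely: the same change on two cores in this assay, an at least 1.6-fold lower number (0.20 log units; that floor lies within the scatter) from compound 2 to compound 3 and an at least 1.2-fold lower number (0.09 log units; that floor lies within the scatter) from compound 1 to compound 4; the limit leaves it open whether they differ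

On these data alone, whether a longer chain such as butanoyloxy, or a chain ending in an amine, would stay this close to compound 3 remains open. As far as these compounds go, how far compound 1 and compound 2 lie beyond their limit also remains open.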